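Swapping 2,6-dichlorophenyl for plain phenyl

The source may report more compounds than this note shows. Statements on the series, on what has been measured and on what is new or still open speak of the compounds shown alone.

Compound 1 `CN(C)CCn1cnnc1-c1cc(Oc2ccc(NC(=O)N/N=C/c3cccc(O)c3)cc2F)ccn1`: in a functional assay on U-87MG ATCC cells (Homo sapiens) for cytotoxicity, read by MTT assay, with a stated time of 72 h (on this read-out higher numbers stand for weaker inhibition and lower numbers for stronger inhibition), compound 1 reaches only the assay limit, > 100000 nM.
Compound 2 `CN(C)CCn1cnnc1-c1cc(Oc2ccc(NC(=O)N/N=C/c3ccc(Cl)cc3)cc2F)ccn1`: compound 2 gives 1370 nM.
Compound 3 `CN(C)CCn1cnnc1-c1cc(Oc2ccc(NC(=O)N/N=C/c3c(Cl)cccc3Cl)cc2F)ccn1`: compound 3 reaches only the assay limit, > 100000 nM.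

Compound 3 therefore stands at the limit, the same limit that compound 1 reports, and only compound 2 gives a readable number. Compound 4 `CN(C)CCn1cnnc1-c1cc(Oc2ccc(NC(=O)N/N=C/c3ccccc3)cc2F)ccn1` differs from compound 3 by phenyl in place of 2,6-dichlorophenyl on a carbon with a double bond to nitrogen. The step that bears most directly is an at least 72-fold higher number from compound 2 to compound 3 (1.86 log units; beyond the scatter), and the mirror step an at least 72-fold lower number from compound 1 to compound 2 (1.86 log units; beyond the scatter) points the same way; both rest on (the limit of > 100000 nM in this assay, at which 2 of the 3 values shown sit). Since phenyl carries neither chlorine substituent, compound 4 is expected to fall off the limit without reaching compound 2. Compound 4 is estimated at 6000 nM, between 1200 nM and 60000 nM. That implies an expected step of an at least 16-fold lower number from compound 3 to compound 4 (1.22 log units; beyond the scatter).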

Compound 4, half-maximal inhibitory concentration: 2250 nM
The estimate for compound 4 lay 2.7-fold (0.43 log units) above the measured number, within the range that was stated.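

In this assay, taking both chlorines off the 2,6-dichlorophenyl ring gives an at least 44-fold lower number from compound 3 to compound 4 (1.64 log units; beyond the scatter), and taking the hydroxy group off the 3-hydroxyphenyl ring gives an at least 44-fold lower number from compound 1 to compound 4 (1.64 log units; beyond the scatter). Both steps start from an assay limit, so they give only minimum sizes: the limit of > 100000 nM in this assay, at which 2 of the 4 values shown sit. Plain phenyl therefore gives a readable number, and removing the single chlorine gives a 1.6-fold higher number from compound 2 to compound 4 (0.22 log units; within the scatter), so a chlorine on this ring is not needed for a readable number.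

As far as these compounds go, whether a ring carrying an amine or a carboxylic acid would also give a readable number remains open.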